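Chloro added to the 4-fluorophenyl of compound 3

The source may hold more compounds than are shown below. What is called first, only, known or untested is meant among the compounds shown, and "the series" means these compounds.

All numbers below are from an assay on CHO-K1 cells for antagonist activity at transient receptor potential cation channel subfamily V member 1 (Homo sapiens), read by FLIPR and calcium flux, with a stated time of 6 min; a higher number here means a weaker inhibitor, a lower number a stronger inhibitor.

Compound 1 `O=C(NCc1cc(C(F)(F)F)nn1-c1ccc(F)c(Cl)c1)Nc1cccc2[nH]ncc12`: in this assay compound 1 gives 0.6 nM
Compound 2 `Cn1ncc2c(NC(=O)NCc3cc(C(F)(F)F)nn3-c3cccc(C(F)(F)F)c3)cccc21`: in this assay compound 2 gives 1.4 nM
Compound 3 `Cn1ncc2c(NC(=O)NCc3cc(C(F)(F)F)nn3-c3ccc(F)cc3)cccc21`: in this assay compound 3 gives 8.4 nM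

Compound 3 stands at the highest number of the three. Going by the values given here, the one measured step of a single change is a 6.0-fold higher number from compound 2 to compound 3 (0.78 log units; beyond the scatter); the value of compound 3 also sits well above that of compound 1, which carries the same 3-chloro-4-fluorophenyl on its core as the new compound but differs at the amide-bearing core as well, so no single step connects them.

Compound 4 `Cn1ncc2c(NC(=O)NCc3cc(C(F)(F)F)nn3-c3ccc(F)c(Cl)c3)cccc21` is compound 3 with chloro in place of hydrogen on an aromatic carbon. Among the compounds with values here, no measured pair isolates this change. What bears on it is that compound 2, carrying a large group on the same ring, gives 1.4 nM, and that compound 1, carrying 3-chloro-4-fluorophenyl, gives 0.6 nM, both lower numbers than compound 3. The chloro is a smaller addition than the step from compound 2 to compound 3 removed, so a step in this assay toward a lower number, smaller than that one, is expected for compound 4: a 4.2-fold lower number from compound 3 to compound 4 (0.62 log units; beyond the scatter). The estimate for compound 4 is 2 nM, with a range from 0.6 nM to 6 nM.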

Compound 4, inhibition constant: 1.9 nM
The estimate for compound 4 lay 1.1-fold (0.02 log units) above the measured number; low and high end bracket the measured number.
By their numbers in this assay, from the lowest: compound 1; then compounds 2 and 4 (each within the scatter of the next); then compound 3.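

In this assay, going by these compounds alone, chloro on the aromatic carbon ortho to the fluoro group gives a 4.4-fold lower number from compound 3 to compound 4 (0.65 log units; beyond the scatter) and so isolates, on the shared core, a step at this position that no earlier pair showed. Changing the aryl group from 3-(trifluoromethyl)phenyl to 3-chloro-4-fluorophenyl gives a 1.4-fold higher number from compound 2 to compound 4 (0.13 log units; within the scatter) and thus leaves the two groups within the scatter of each other, so in this pair the single chlorine atom matches the trifluoromethyl-bearing ring. With 3-chloro-4-fluorophenyl held constant, a methyl in place of hydrogen on the aromatic nitrogen gives a 3.2-fold higher number from compound 1 to compound 4 (0.50 log units; beyond the scatter) as a modest step, the first view of that nitrogen with the aryl group fixed.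

No measurement at hand explains the size of any of these steps.

Still open, as far as these compounds go, is whether bromo or methoxy in place of the chloro would keep the value of compound 4, and whether the step from hydrogen to methyl on the aromatic nitrogen has the same size with 3-(trifluoromethyl)phenyl as the aryl group.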